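Moving the nitrile on a benzyloxy group: compound 3 to compound 4

This account rests on a few compounds, and the source may have more. Where it says the series, first, only, none or still open, it means among the compounds named here.

Measured so far:
compound 1 `Cc1nn(-c2ncnc3nc[nH]c23)c2c1C(c1ccc(OC(C)C)cc1)CC(=O)N2` gives 18 nM
compound 2 `Cc1nn(-c2ncnc3nc[nH]c23)c2c1C(c1ccc(F)cc1Cl)CC(=O)N2` gives 9 nM
compound 3 `Cc1nn(-c2ncnc3nc[nH]c23)c2c1C(OCc1ccccc1C#N)CC(=O)N2` gives 8 nM

In a functional assay on HEK293 cells for agonist activity at G-protein coupled receptor 39 (Homo sapiens), read by scintillation proximity assay and inositol phosphate accumulation, with a stated time of 75 min, in the presence of a further agent that is not named here (a higher number here means that more compound is needed for the effect, a lower number that less compound is needed), compound 3 has the lowest number of the three, though compound 2 sits within the scatter of it, and only a 2.3-fold lower number from compound 1 to compound 3 (0.35 log units; beyond the scatter) is a real step. Compound 4 `Cc1nn(-c2ncnc3nc[nH]c23)c2c1C(OCc1ccc(C#N)cc1)CC(=O)N2` differs from compound 3 by 4-cyanophenyl in place of 2-cyanophenyl on a saturated chain carbon bound to an oxygen on a saturated carbon. Within the data shown here, no measured step moves a nitrile on a ring; the steps of a 2.3-fold lower number from compound 1 to compound 3 (0.35 log units; beyond the scatter) and a 1.1-fold lower number from compound 2 to compound 3 (0.05 log units; within the scatter) exchanged the whole group on the saturated ring carbon and stayed modest. The step of a 1.3-fold higher number from compound 3 to compound 4 (0.10 log units; within the scatter) is therefore expected to stay within the scatter, with no clear direction. Compound 4 is expected to give 10 nM, in a range from 4 nM to 25 nM.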

Compound 4, half-maximal effective concentration: 4 nM
Compound 4: middle estimate off by 2.5-fold (0.40 log units), on the high side, and the stated range covers the measured number.
By their numbers in this assay, from the lowest: compounds 4, 3, 2 and 1 (each within the scatter of the next, the first and the last beyond it).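

In this assay, the first nitrile move, 4-cyanophenyl in place of 2-cyanophenyl, gives a 2.0-fold lower number from compound 3 to compound 4 (0.30 log units; within the scatter), so the place of the nitrile on this ring makes no clear difference. The (4-cyanobenzyl)oxy group does separate from 2-chloro-4-fluorophenyl, with a 2.3-fold lower number from compound 2 to compound 4 (0.35 log units; beyond the scatter), a gap that the (2-cyanobenzyl)oxy group did not open, and its exchange for 4-isopropoxyphenyl gives a 4.5-fold lower number from compound 1 to compound 4 (0.65 log units; beyond the scatter). No measurement here explains these numbers.

Still open, going by these compounds, is how an amine or a carboxylic acid in place of the nitrile would read, and how a longer chain in place of the benzyl group would read.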